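The source may hold more compounds than are shown below. What is called first, only, known or untested is meant among the compounds shown, and "the series" means these compounds.

Working notes on the series in an ADME assay on cells (Hepatocyte, Rattus norvegicus) for pharmacokinetics; a lower number here means slower removal, a higher number faster removal of the compound. Compound 3 `O=S(=O)(c1ccc(F)cc1)c1cc(F)c(O)c2ncccc12` gives 15 uL/min, the highest of the three numbers. Compound 1 `O=S(=O)(c1ccc(C(F)(F)F)cc1)c1cc(F)c(O)c2ncccc12` gives 12 uL/min. The step of a 1.3-fold higher number from compound 1 to compound 3 (0.10 log units; within the scatter) lies within the scatter. Compound 2 `O=S(=O)(c1ccc(F)cc1)c1cc(Cl)c(O)c2ncccc12` gives 4 uL/min. The step of a 3.8-fold higher number from compound 2 to compound 3 (0.57 log units; beyond the scatter) is the only one beyond the scatter. Both steps exchange the group on the aromatic carbon para to a large group, the same place that separates compound 3 from compound 4.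

Compound 4 `Cc1ccc(S(=O)(=O)c2cc(F)c(O)c3ncccc23)cc1` awaits measurement. It differs from compound 3 by methyl in place of fluoro on an aromatic carbon. The two measured steps bear on this change only in that they alter the same position: trifluoromethyl to fluoro gave a 1.3-fold higher number from compound 1 to compound 3 (0.10 log units; within the scatter), while chloro to fluoro gave a 3.8-fold higher number from compound 2 to compound 3 (0.57 log units; beyond the scatter). Methyl itself has no precedent in the set, so nothing anchors a direction, and one of the two comparable exchanges moved the number very little. The expectation for compound 4 in this assay is therefore a step of no change at the digits printed from compound 3 to compound 4 (within the scatter), not beyond the scatter. Compound 4 is estimated at 15 uL/min, with a range from 7 uL/min to 32 uL/min in this assay.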

Compound 4, intrinsic clearance in a liver preparation (reported as CLH), per the amount of preparation that the assay uses: 36 uL/min
For compound 4 the middle estimate is 2.4-fold (0.38 log units) below the measured one; the whole stated range lies below it.
By their numbers in this assay, from the lowest: compound 2; then compounds 1 and 3 (each within the scatter of the next); then compound 4.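

In this assay the change from 4-fluorophenyl to 4-methylphenyl gives a 2.4-fold higher number from compound 3 to compound 4 (0.38 log units; beyond the scatter) and so shows that this position, on an aromatic carbon para to a large group, does respond to the group it carries, which the earlier step of a 1.3-fold higher number from compound 1 to compound 3 (0.10 log units; within the scatter) did not show, since it stayed within the scatter. Methyl in place of trifluoromethyl gives a 3.0-fold higher number from compound 1 to compound 4 (0.48 log units; beyond the scatter) and points the same way, so among the three groups read here, methyl stands apart from fluoro and trifluoromethyl, which sit within the scatter of each other, and the two fluorine-bearing groups share the lower numbers. Nothing at hand accounts for the separation of methyl from the other two groups.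

The compounds shown leave open whether the higher number belongs to methyl alone or extends to a longer chain such as ethyl, or to a methoxy group or an amine at the same place. They also leave open whether methyl at this place gives a step of similar size when chloro replaces fluoro elsewhere on the shared core.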